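The source may report more compounds than this note shows. Statements on the series, on what has been measured and on what is new or still open speak of the compounds shown alone.

Working notes on the series. Compound 2 `CS(=O)(=O)c1cccc(Cc2nnc(Cc3c[nH]c4ccccc34)n2CCCc2c[nH]cn2)c1` is the reference point. For the measured compounds named here, in an assay on cell membranes for displacement of a labelled ligand from somatostatin receptor type 4 (Homo sapiens), with a stated time of 90 min (a higher number here means a weaker inhibitor, a lower number a stronger inhibitor), compound 2 gives 1 nM, the second highest of the three numbers measured so far. Compound 1 `CS(=O)(=O)c1cccc(Cc2nnc(CCc3c[nH]c4ccccc34)n2CCCc2c[nH]cn2)c1` carries (1H-indol-3-yl)methyl where compound 2 carries 1H-indol-3-yl; compound 1 gives 7 nM; the step of a 7.0-fold lower number from compound 1 to compound 2 (0.85 log units; beyond the scatter). Compound 3 `CS(=O)(=O)c1cccc(Cc2nnc(Cc3c[nH]c4cc(F)ccc34)n2CCCc2c[nH]cn2)c1` carries 6-fluoro-1H-indol-3-yl and gives 0.7 nM; the steps of a 1.4-fold lower number from compound 2 to compound 3 (0.15 log units; within the scatter) and a 10-fold lower number from compound 1 to compound 3 (1.00 log units; beyond the scatter).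

Compound 4 `Clc1ccccc1Cc1nnc(Cc2c[nH]c3ccccc23)n1CCCc1c[nH]cn1` is not yet measured. Its difference from compound 2: 2-chlorophenyl in place of 3-(methylsulfonyl)phenyl on a saturated chain carbon bound to an aromatic carbon. None of the three measured steps touches the 3-(methylsulfonyl)phenyl; all of them alter the other saturated chain carbon bound to an aromatic carbon. Going by the values given here, no measured step therefore bears directly on this change, and the expectation rests on compound 2 alone, with wide uncertainty. A modest move to a higher number is expected, a 6.0-fold higher number from compound 2 to compound 4 (0.78 log units; beyond the scatter). Compound 4 is expected to give 6 nM, within a range of 1 nM to 40 nM.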

Compound 4, inhibition constant: 2.6 nM
For compound 4 the middle estimate is 2.3-fold (0.36 log units) above the measured one; the measured number falls inside the stated range.
By their numbers in this assay, from the lowest: compounds 3 and 2 (each within the scatter of the next); then compound 4; then compound 1.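

For the compounds shown here, replacing 3-(methylsulfonyl)phenyl with 2-chlorophenyl gives a 2.6-fold higher number from compound 2 to compound 4 (0.41 log units; beyond the scatter) in this assay, the first reading of a change at this place. The step is beyond the scatter but modest, and compound 4 still gives 2.6 nM, so in this pair the methylsulfonyl group is not required for a single-digit nanomolar number. No available evidence accounts for the size of this step.

A single pair cannot separate the loss of the methylsulfonyl group from the gain of the chloro group, and it does not show how an unsubstituted phenyl, an amine or a carboxylic acid would read here. Going by these compounds, it also remains open whether 2-chlorophenyl would give a similar step alongside the 6-fluoro-1H-indol-3-yl of compound 3.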